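A few compounds are considered here, and "the series" means these few. Any claim that something is new, unique, unknown or untested is made for them only; others in the source may bear on it.

Compound 3 `COc1ccccc1C(=O)c1sc2nc(-c3cccs3)ccc2c1N` gives the lowest number of the two numbers measured in a functional assay on WI-38 VA13 cells (Homo sapiens) for cytotoxicity (on this read-out higher numbers stand for an effect only at larger amounts of compound and lower numbers for an effect already at smaller amounts), with 0.059 ug/mL. The nearest measured number belongs to compound 1 `CNc1c(C(=O)c2ccccc2)sc2nc(-c3cccs3)ccc12`, which in this assay gives 0.42 ug/mL; compound 3 and compound 1 differ in more than one place, so the gap between them is only a comparison of two values. Compound 2 `CN(C)c1c(C(=O)c2ccccc2)sc2nc(-c3cccs3)ccc12` reaches only a limit in this assay, > 4 ug/mL. Going by the values given here, the single measured step, an at least 9.5-fold higher number from compound 1 to compound 2 (0.97 log units; beyond the scatter), concerns a different part of the shared core and does not bear on the change now followed; it is noted only as the case where one value sits at the limit of > 4 ug/mL in this assay, at which 1 of the 3 values shown sits.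

Compound 4 `COc1ccc(C(=O)c2sc3nc(-c4cccs4)ccc3c2N)cc1` differs from compound 3 by 4-methoxyphenyl in place of 2-methoxyphenyl on a carbonyl carbon. Among the compounds with values here, no measured step touches the methoxyphenyl group on the carbonyl carbon, so the direction of the change is open. Compound 4 is therefore expected to stay within a modest distance of compound 3 in this assay, the step of a 2.5-fold higher number from compound 3 to compound 4 (0.41 log units; beyond the scatter) being the estimate. The expected value for compound 4 is 0.15 ug/mL, between 0.03 ug/mL and 0.8 ug/mL.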

Compound 4, half-maximal effective concentration: 0.77 ug/mL
Estimate against measurement, compound 4: 5.1-fold (0.71 log units) below, within the range that was stated.
By their numbers in this assay, from the lowest: compound 3; then compounds 1 and 4 (each within the scatter of the next). At a limit, above all of these: compound 2.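

With 4-methoxyphenyl in place of 2-methoxyphenyl on the carbonyl carbon, this assay shows a 13-fold higher number from compound 3 to compound 4 (1.12 log units; beyond the scatter). Going by these compounds alone, this is the first measured step at this place, since the earlier step concerned only a methyl on a nitrogen of the core. It shows that the read-out responds strongly here even when the group that leaves and the group that enters have the same atoms, joined differently. Nothing measured among these compounds accounts for the size of this step. The compounds shown leave open how a chlorophenyl or a hydroxyphenyl group would stand on the same carbonyl carbon. They also leave open whether the same exchange of methoxyphenyl groups would give a step of similar size with the methylamino group of compound 1 on the core.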